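Phenyl to 4-methylphenyl: a small added group

This account rests on a few compounds, and the source may have more. Where it says the series, first, only, none or still open, it means among the compounds named here.

compound 1 `COc1cc(C2=NOC(COCc3cn(Cc4cc(C)cnc4Cl)nn3)C2)cc(OC)c1OC`: 50500 nM
compound 2 `COc1cc(C2=NOC(COCc3cn(Cc4cc(-c5ccccc5)cnc4Cl)nn3)C2)cc(OC)c1OC`: 7300 nM

In a functional assay on HeLa cells (Homo sapiens) for cytotoxicity, read by MTT assay, with a stated time of 48 h (on this read-out lower numbers stand for stronger inhibition and higher numbers for weaker inhibition), compound 2 stands lowest of the two measured compounds at 7300 nM and is therefore the stronger of the pair. The next compound to consider is compound 3 `COc1cc(C2=NOC(COCc3cn(Cc4cc(-c5ccc(C)cc5)cnc4Cl)nn3)C2)cc(OC)c1OC` and the change that leads to it is methyl in place of hydrogen on an aromatic carbon in the form of methyl in place of hydrogen on an aromatic carbon, which turns phenyl to 4-methylphenyl.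

Within the data shown here, one measured step bears on this, and only loosely: a 6.9-fold lower number from compound 1 to compound 2 (0.84 log units; beyond the scatter) with phenyl in place of methyl on an aromatic carbon. That swap brought in a whole phenyl, a much larger change than the single methyl added here. Among the measured compounds shown here, no measured compound carries anything on this phenyl, so the data give no firm direction for the new methyl. The estimated outcome is a 1.1-fold lower number from compound 2 to compound 3 (0.05 log units; within the scatter) and so no expected shift beyond the usual scatter. For compound 3 the estimate is 6500 nM with 2500 nM to 17000 nM as the expected range.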

Compound 3, half-maximal inhibitory concentration: 9700 nM
For compound 3 the middle estimate is 1.5-fold (0.17 log units) below the measured one; the range from low to high includes it.
By their numbers in this assay, from the lowest: compounds 2 and 3 (each within the scatter of the next); then compound 1.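

In this assay the methyl added to the phenyl, on the ring carbon para to a large group, gives a 1.3-fold higher number from compound 2 to compound 3 (0.12 log units; within the scatter) and so leaves the reading unchanged within normal repeat variation. Among these compounds, this is the first sign that this phenyl can carry a small added group without a readable loss or gain in this cell test, though it rests on a single example. The advantage over the small methyl on the core also remains, with a 5.2-fold lower number from compound 1 to compound 3 (0.72 log units; beyond the scatter) still beyond the scatter, so adding this methyl to the phenyl does not undo what the phenyl brought. The data offer no explanation for why this methyl leaves the reading where it is.

Going by these compounds, what a larger or different group would do at this carbon stays open: a methoxy, a fluorine, an amine or a carboxylic acid on this phenyl could give a different answer from a methyl. On these data alone, the effect of a methyl on the other carbons of the phenyl also remains unknown from these three compounds.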